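A few compounds are considered here, and "the series" means these few. Any claim that something is new, unique, unknown or untested is made for them only; others in the source may bear on it.

The measured compounds so far:

compound 1, `N#CC1CN1C(=O)Nc1ccc(F)cc1`: 5900 nM
compound 2, `N#CC1CN1C(=O)Nc1cccc2ccccc12`: 8900 nM
compound 3, `CCNC(=O)N1CC1C#N`: 26000 nM

All three share a small core carrying a nitrile, and they were tested in a functional assay on RPMI-8226 cells (Homo sapiens) for inhibition; a higher number here means a weaker inhibitor, a lower number a stronger inhibitor. Compound 1 gives 5900 nM, the lowest number of the three. Compound 2 gives 8900 nM, which lies within the usual scatter of the number for compound 1, so the two cannot be ranked against each other. Compound 3 gives 26000 nM, a gap from compound 1 that goes beyond the scatter.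

The next compound, compound 4, `N#CC1CN1C(=O)Nc1ccc(S(N)(=O)=O)cc1`, has not yet been measured in this assay. It differs from compound 1 in one place: sulfamoyl in place of fluoro on an aromatic carbon. Within the data shown here, no measured pair shows a change of this kind, so the data give no direction for it. In the absence of such a comparison, the step is expected to be modest, with either direction possible, and its size is estimated as a 1.2-fold higher number from compound 1 to compound 4 (0.07 log units; within the scatter). Compound 4 is therefore expected to give about 7000 nM, in a range from 2000 nM to 25000 nM.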

Compound 4, half-maximal inhibitory concentration: > 38000 nM
Compound 4: only a limit was reported; the forecaster's own chance of this, stated with the estimate: 10%; middle value at least 5.4-fold (0.73 log units) from the limit.
By their numbers in this assay, from the lowest: compounds 1 and 2 (each within the scatter of the next); then compound 3. At a limit, above all of these: compound 4.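

The earlier compounds shown here offered no pair differing in one place. Here, on the aromatic carbon para to a group of 8 heavy atoms, sulfamoyl in place of fluoro gives an at least 6.4-fold higher number from compound 1 to compound 4 (0.80 log units; beyond the scatter), so what sits on this carbon can move the number well beyond the scatter. In this assay compound 4 gives > 38000 nM, and this is a limit of the assay, not a number, so the step marks only the least it can be: the limit of > 38000 nM in this assay, at which 1 of the 4 values shown sits.

The compounds shown leave open how other groups on this carbon, such as an amine, a hydroxyl or a carboxylic acid, would compare with fluoro. They also leave open whether a plain hydrogen there would give a number close to that of compound 1.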